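The source may report more compounds than this note shows. Statements on the series, on what has been measured and on what is new or still open speak of the compounds shown alone.

Compound 1 `Clc1ccc(-c2nnc(SCCCN3CCN(c4nc5ccccc5o4)CC3)o2)cc1`: 99700 nM
Compound 2 `Fc1ccc(-c2nnc(SCCCN3CCN(c4nc5ccccc5o4)CC3)o2)cc1`: 52300 nM
Compound 3 `Oc1ccc(-c2nnc(SCCCN3CCN(c4nc5ccccc5o4)CC3)o2)cc1`: 260000 nM

In a functional assay on MCF7 cells (Homo sapiens) for inhibition, read by MTT assay, with a stated time of 72 h (on this read-out higher numbers stand for weaker inhibition and lower numbers for stronger inhibition), compound 1 gives 99700 nM, the second highest of the three numbers. Swapping its chloro for fluoro gives a 1.9-fold lower number from compound 1 to compound 2 (0.28 log units; within the scatter), while hydroxy gives a 2.6-fold higher number from compound 1 to compound 3 (0.42 log units; beyond the scatter).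

Compound 4 `Clc1ccc(-c2nnc(SCCCN3CCN(c4nc5ccccc5s4)CC3)o2)cc1`, not yet measured, carries 1,3-benzothiazol-2-yl in place of 1,3-benzoxazol-2-yl on an amine nitrogen in a ring. Going by the values given here, no measured step touches this group. The steps above, all on an aromatic carbon, show only how far values moved in this small set, and they give no direction. A step beyond the scatter is therefore not expected in this assay. The expected change is a 1.2-fold lower number from compound 1 to compound 4 (0.10 log units; within the scatter). For compound 4 the estimated value is 80000 nM, with an expected range of 30000 nM to 210000 nM.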

Compound 4, half-maximal inhibitory concentration: 116000 nM
Estimate against measurement, compound 4: 1.5-fold (0.16 log units) below, within the range that was stated.
By their numbers in this assay, from the lowest: compounds 2, 1 and 4 (each within the scatter of the next, the first and the last beyond it); then compound 3.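

In this assay, going by these compounds alone, the earlier compounds varied only the group on the aromatic carbon, whereas this pair tests the group on the amine nitrogen in a ring. Placing 1,3-benzothiazol-2-yl there instead of 1,3-benzoxazol-2-yl gives a 1.2-fold higher number from compound 1 to compound 4 (0.07 log units; within the scatter), so with chloro kept, sulfur in place of oxygen in this group leaves the two compounds indistinguishable. Nothing measured here offers an explanation for this result.

From the compounds shown here alone, whether the swap behaves alike with fluoro or hydroxy in place of chloro stays open. So does the effect of a plain phenyl or a pyridin-2-yl group on that nitrogen.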